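The source may report more compounds than this note shows. Statements on the series, on what has been measured and on what is new or still open speak of the compounds shown alone.

The study asks how strongly each compound blocks seizures in a living animal, measured in a functional assay on the whole organism (strain albino) with Rattus norvegicus as the target, in the maximal electroshock model, with a stated time of 1 h, at a dose of 30 mg/kg by the intraperitoneal route; on this read-out lower numbers stand for less inhibition and higher numbers for more inhibition at the one dose given (going by the name of the read-out). Among the measured compounds shown here, compound 1 `CCOC(=O)CNn1c(C)nc2ccc(Br)cc2c1=O` has the lower of the two numbers measured so far: in this assay compound 1 gives 20%. Compound 2 `COc1ccc(C2SCC(=O)N2c2nnc(CNn3c(C)nc4ccccc4c3=O)s2)cc1`, which carries a much larger group on the shared core, gives 60% in this assay, a number that stands beyond the usual scatter above that of compound 1. Nothing connects these two compounds by a single change, so their two values are all that can be said of them.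

Compound 3 `Cc1nc2ccc(Br)cc2c(=O)n1NCC(=O)NNC(N)=S` has not yet been measured in this assay. It is compound 1 with one change: a group of 5 heavy atoms (1 carbon, 3 nitrogen, 1 sulfur; no ring) in place of a group of 3 heavy atoms (2 carbon, 1 oxygen; no ring), on a carbonyl carbon. For the measured compounds named here, no single-change step among the measured compounds shows what such an exchange does, so the size of the step has to be estimated. The step from compound 1 to compound 3 is expected to be a moderate rise, a number 20 percentage points higher from compound 1 to compound 3 (beyond the scatter), staying within the span of the two measured values. Compound 3 is thus expected to give about 40% in this assay, with a range from 10% to 70%.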

Compound 3, a percentage reported as inhibition, in the whole organism at one dose (the size of the read-out at that dose, not a potency): 30%
Beside the measured number, compound 3's estimate is 10 percentage points above it, within the range that was stated.
By their numbers in this assay, from the lowest: compounds 1 and 3 (each within the scatter of the next); then compound 2.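

Swapping the ethoxy group on this carbonyl carbon, whose other neighbour is a saturated chain carbon, gives the first single change that can be read in this assay: it produces a number 10 percentage points higher from compound 1 to compound 3 (within the scatter). At this position and this one dose, the read-out therefore does not separate the two groups, even though the entering group has 5 heavy atoms against 3 and 3 hydrogen-bond donors against 0. No measurement available here explains this result or bears on what either group does in the animal.

The compounds shown leave open what an amine, a carboxylic acid or a longer chain would do on the same carbonyl carbon, so one exchange cannot show how this position responds to change in general. They also leave open whether the ethoxy group and the entering group would stay this close at another dose or another time after dosing, or whether the same exchange would give a similar step on a different core.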